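Chloro for methoxy on the longer-linked analogue

The compounds below may be only part of what the source reports. "The series", "measured", "known", "first", "only" and "open" are said of these compounds alone.

Among the compounds with values here, compound 3 `COc1ccccc1N1CCN(CCCCn2ncc(N3CCN(C(=O)c4ccco4)CC3)c(Cl)c2=O)CC1` gives 33.5 nM in an assay on cell membranes for binding affinity to Adrenergic receptor alpha-1 (Rattus norvegicus), read by radioligand binding (on this read-out lower numbers stand for stronger inhibition and higher numbers for weaker inhibition), the highest of the three numbers measured so far. Compound 1 `COc1ccccc1N1CCN(CCn2ncc(N3CCN(C(=O)c4ccco4)CC3)c(Cl)c2=O)CC1` gives 33 nM, within the scatter of compound 3. Compound 2 `O=C(c1ccco1)N1CCN(c2cnn(CCN3CCN(c4ccccc4Cl)CC3)c(=O)c2Cl)CC1` gives 3.9 nM, a number beyond the scatter below both of them. Compound 4 `O=C(c1ccco1)N1CCN(c2cnn(CCCCN3CCN(c4ccccc4Cl)CC3)c(=O)c2Cl)CC1` differs from compound 3 by one change only: chloro in place of methoxy on an aromatic carbon. Within the data shown here, the single measured step with the same exchange, an 8.5-fold lower number from compound 1 to compound 2 (0.93 log units; beyond the scatter), bears directly on this case and is the only guide available. A step of comparable size and direction is therefore expected here, namely an 8.4-fold lower number from compound 3 to compound 4 (0.92 log units; beyond the scatter). On that basis compound 4 is estimated at 4 nM, with a range from 1.5 nM to 11 nM.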

Compound 4, inhibition constant: 19 nM
The estimate for compound 4 lay 4.8-fold (0.68 log units) below the measured number; the measured number lies above the stated range.
By their numbers in this assay, from the lowest: compound 2; then compounds 4, 1 and 3 (each within the scatter of the next).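

The exchange of 2-methoxyphenyl for 2-chlorophenyl does not carry a fixed step in this assay: on the longer-linked core it gives a 1.8-fold lower number from compound 3 to compound 4 (0.25 log units; within the scatter), so the two groups cannot be told apart there. The size of the step at this position therefore depends on the core, which a single earlier pair could not show: the same change on two cores in this assay, an 8.5-fold lower number (0.93 log units; beyond the scatter) from compound 1 to compound 2 and a 1.8-fold lower number (0.25 log units; within the scatter) from compound 3 to compound 4, 4.8-fold (0.68 log units) apart, beyond the scatter of two such steps

Two pairs cannot tell whether the step shrinks steadily as the chain grows. On these data alone, a chain of intermediate length, and a fluoro or methyl group at this place on both cores, remain open.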